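The source may hold more compounds than are shown below. What is called first, only, known or untested is meant among the compounds shown, and "the series" means these compounds.

Measured in a functional assay on A2780 cells (Homo sapiens) for inhibition, read by sulforhodamine B assay; on this read-out lower numbers stand for stronger inhibition of growth and higher numbers for weaker inhibition of growth:
- compound 1 `COc1ccc(-c2ccc(-c3ccc(-c4nc5cc(C)ccc5[nH]4)cc3)cc2)cc1OC`: 2130 nM
- compound 2 `Fc1ccc(-c2ccc(-c3ccc(-c4nc5ccccc5[nH]4)cc3)cc2)cc1`: 48200 nM

Within the data shown here, with only two measured compounds, the picture is thin. Compound 2, at 48200 nM, has the higher number of the pair and so the weaker inhibition of growth. Its gap to compound 1, at 2130 nM, lies beyond the usual scatter of repeated measurements. These two compounds differ in more than one place, however, so their gap cannot be pinned on any single group.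

The next compound to be tested is compound 3 `CN(C)c1ccc(-c2ccc(-c3ccc(-c4nc5ccccc5[nH]4)cc3)cc2)cc1`. It keeps the rest of compound 2 and carries dimethylamino in place of fluoro on an aromatic carbon, para to a large group (dimethylamino in place of fluoro on an aromatic carbon). Among the measured compounds shown here, no single-place step has been measured in this set, so any forecast is rough. Compound 2 sits high at 48200 nM, and compound 1 shows that a related structure can reach 2130 nM, so a move toward stronger inhibition seems more likely than a move the other way. The expected change is a 6.9-fold lower number from compound 2 to compound 3 (0.84 log units; beyond the scatter). For compound 3 the estimate is 7000 nM, with an expected range of 1200 nM to 40000 nM.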

Compound 3, concentration for 50% growth inhibition: 100000 nM
Compound 3: middle estimate off by 14-fold (1.15 log units), on the low side; the whole stated range lies below it.
By their numbers in this assay, from the lowest: compound 1; then compound 2; then compound 3.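

Among these compounds, this is the first step in the set where only one place changes: going from 4-fluorophenyl to 4-(dimethylamino)phenyl, on an aromatic carbon para to a large group, gives a 2.1-fold higher number from compound 2 to compound 3 (0.32 log units; beyond the scatter) in this assay and so a modest move toward weaker inhibition of growth, one that lies beyond the usual scatter. The position is therefore not silent, since replacing the single fluorine atom with the three heavy atoms of dimethylamino does shift the read-out, though only slightly, and on this core that swap does not bring the number down. No measurement at hand explains why the step goes in this direction.

On these data alone, whether a different group at this same position, such as a primary amine or a carboxylic acid, would lower the number or raise it further remains open. Also open, as far as these compounds go, is what a single change elsewhere on the shared core would do, since compound 1 differs from compound 2 in more than one place and its lower number cannot be assigned to any one of those differences.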